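A Methyl Added to the Chloro Analogue

The compounds below may be only part of what the source reports. "The series", "measured", "known", "first", "only" and "open" are said of these compounds alone.

Three compounds built on one shared core have been tested in a functional assay on the whole organism for inhibition, with Rattus norvegicus as the target, read by paw edema, with a stated time of 30 min, at a dose of 80 mg/kg by the oral route; a lower number here means a weaker effect, a higher number a stronger effect of the compound at the dose given:

Compound 1, `COc1ccc(OCC2=NCCO2)cc1`: 64.1%
Compound 2, `Clc1ccc(OCC2=NCCO2)cc1`: 94.1%
Compound 3, `Clc1ccccc1OCC1=NCCO1`: 45.5%

Compound 2 stands highest of the three. Going by the values given here, its nearest neighbour is compound 1, and the one measured step between them, a number 30 percentage points higher from compound 1 to compound 2 (beyond the scatter), lies beyond the scatter. Among the compounds with values here, compound 3 sits further down still, though no single-point step links it to compound 2.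

The next compound, compound 4, `Cc1cc(OCC2=NCCO2)ccc1Cl`, differs from compound 2 in one place: methyl in place of hydrogen on an aromatic carbon.

Within the data shown here, none of the measured steps bears on this change. Among the measured compounds shown here, the step from compound 1 to compound 2 swapped one group for another, whereas here a methyl is simply added, and no pair in the measured set shows what a methyl on an aromatic carbon does. The expectation therefore rests only on where compound 2 stands: because compound 2 already gives 94.1%, there is little room for a rise, so a step of about a number 8.1 percentage points lower from compound 2 to compound 4 (within the scatter) is expected, which is likely to remain within the scatter. Compound 4 is thus estimated at 86%, with a range from 65% to 98%.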

Compound 4, a percentage reported as inhibition, in the whole organism at one dose (the size of the read-out at that dose, not a potency): 77.1%
For compound 4 the middle estimate is 8.9 percentage points above the measured one; measured number inside the range.
By their numbers in this assay, from the lowest: compound 3; then compound 1; then compound 4; then compound 2.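

Going by these compounds alone, this is the first measured look at what a methyl does on an aromatic carbon of this series. Placed ortho to the chloro group and meta to the group of 7 heavy atoms, it gives a number 17 percentage points lower from compound 2 to compound 4 (beyond the scatter) in this assay, so this position is not neutral: a change of only 1 heavy atom is enough to move the read-out beyond the usual scatter, although compound 4 still gives 77.1%. No measurement shown here explains why the added methyl lowers the number, so the result stands as an observation without an established cause.

The compounds shown leave open whether this drop is specific to methyl or would also follow from other groups at the same carbon, such as a hydroxyl, an amine or a longer chain like ethyl. They also leave open whether a methyl on another carbon of the same ring would give a similar step, and, with only one oral dose read, how the compounds would compare across a range of doses.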